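Side-chain removal from compound 2: working notes

The source may hold more compounds than are shown below. What is called first, only, known or untested is meant among the compounds shown, and "the series" means these compounds.

Compound 1 `O=C1c2c[n+]([O-])c3ccccc3c2C(=O)c2c1c1ccccc1n2Cc1cn(C[C@H](O)CO)nn1` gives 1030 nM in a functional assay on A549 cells (Homo sapiens) for cytotoxicity, read by MTT assay, with a stated time of 72 h; on this read-out higher numbers stand for weaker inhibition and lower numbers for stronger inhibition
Compound 2 `CN1CCN(CCCCCn2c3c(c4ccccc42)C(=O)c2c[n+]([O-])c4ccccc4c2C3=O)CC1` gives 870 nM in this assay

Going by the values given here, compound 2 stands level with compound 1 in this assay, the only measured step being a 1.2-fold lower number from compound 1 to compound 2 (0.07 log units; within the scatter) between them. Compound 3 `O=C1c2c[n+]([O-])c3ccccc3c2C(=O)c2[nH]c3ccccc3c21` differs from compound 2 by hydrogen in place of 5-(4-methylpiperazin-1-yl)pentyl on an aromatic nitrogen. The measured step, a 1.2-fold lower number from compound 1 to compound 2 (0.07 log units; within the scatter), exchanges one substituent for another and removes none, so it is only a weak guide here. The expected change is a 1.0-fold higher number from compound 2 to compound 3 (0.01 log units; within the scatter), with no shift beyond the scatter and no direction favoured. Compound 3 is estimated at 900 nM within an expected range of 250 nM to 3500 nM overall.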

Compound 3, half-maximal inhibitory concentration: 320 nM
For compound 3 the middle estimate is 2.8-fold (0.45 log units) above the measured one, and the stated range covers the measured number.
By their numbers in this assay, from the lowest: compound 3; then compounds 2 and 1 (each within the scatter of the next).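

In this assay, going by these compounds alone, this position gives the first change beyond the scatter, with a 2.7-fold lower number from compound 2 to compound 3 (0.43 log units; beyond the scatter) and a 3.2-fold lower number from compound 1 to compound 3 (0.51 log units; beyond the scatter) as the aromatic nitrogen goes to hydrogen. Neither 5-(4-methylpiperazin-1-yl)pentyl nor (1-(2,3-dihydroxypropyl)-1H-1,2,3-triazol-4-yl)methyl is needed on this nitrogen for a low number on this read-out. No measured evidence bears on the reason for this difference.

Open, as far as these compounds go, is whether a methyl group on this nitrogen would keep the number of compound 3. Also open, from the compounds shown here alone, is how a short chain ending in a carboxylic acid would read here.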